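The source may report more compounds than this note shows. Statements on the series, on what has been measured and on what is new or still open speak of the compounds shown alone.

Measured so far in an assay on microsomes for inhibition of acyl-CoA:cholesterol acyltransferase (Oryctolagus cuniculus); on this read-out higher numbers stand for weaker inhibition and lower numbers for stronger inhibition:
compound 1 `CC(C)c1cccc(C(C)C)c1NC(=O)NCC1(c2cccc([N+](=O)[O-])c2)CCCC1`: 51 nM
compound 2 `COC(=O)c1ccc(C2(CNC(=O)Nc3c(C(C)C)cccc3C(C)C)CCCC2)cc1`: 360 nM

Compound 2 stands highest of these two numbers, compound 1 lower. Within the data shown here, the single measured step, a 7.1-fold higher number from compound 1 to compound 2 (0.85 log units; beyond the scatter), is the only one that bears on the next change and was modest. Compound 3 `CC(C)c1cccc(C(C)C)c1NC(=O)NCC1(c2cccc(CO)c2)CCCC1` differs from compound 2 by 3-(hydroxymethyl)phenyl in place of 4-(methoxycarbonyl)phenyl on a saturated ring carbon. Among the measured compounds shown here, the entering group appears in no measured compound, so the direction is uncertain; a lower number than compound 2 is expected, partway back toward compound 1. Compound 3 is therefore estimated at 150 nM, range 40 nM to 600 nM, meaning a 2.4-fold lower number from compound 2 to compound 3 (0.38 log units; beyond the scatter).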

Compound 3, half-maximal inhibitory concentration: 15 nM
Estimate against measurement, compound 3: 10-fold (1.00 log units) above; the whole stated range lies above it.
By their numbers in this assay, from the lowest: compound 3; then compound 1; then compound 2.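

In this assay the change to 3-(hydroxymethyl)phenyl on the saturated ring carbon gives a 24-fold lower number from compound 2 to compound 3 (1.38 log units; beyond the scatter) and, as hydroxymethyl in place of nitro on an aromatic carbon, also gives a 3.4-fold lower number from compound 1 to compound 3 (0.53 log units; beyond the scatter). Compound 3 therefore holds the lowest number of the three, and a low number at this position does not depend on nitro. Nothing measured here explains either step.

As far as these compounds go, whether the higher number of compound 2 follows the methoxycarbonyl group or its 4- placement stays open. A 3-(methoxycarbonyl)phenyl would separate these, while a carboxylic acid or an amine in place of hydroxymethyl would test how specific that group is.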